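Cyclohexylmethyl in place of benzyl on the hydroxamate series

A few compounds are considered here, and "the series" means these few. Any claim that something is new, unique, unknown or untested is made for them only; others in the source may bear on it.

Going by the values given here, compound 2 `O=C(CCCCCCn1cc(Nc2ncc3ccn(Cc4ccccc4)c3n2)cn1)NO` gives 12.5 nM in an assay on isolated protein for inhibition of protein deacetylase HDAC6 (Homo sapiens), with a stated time of 60 min (a lower number here means a stronger inhibitor, a higher number a weaker inhibitor), the lowest of the three numbers so far. Compound 1 `O=C(CCCCCn1cc(Nc2ncc3ccn(Cc4ccccc4)c3n2)cn1)NO` gives 13.8 nM, and the step of a 1.1-fold lower number from compound 1 to compound 2 (0.04 log units; within the scatter) is within the scatter, so the two compounds cannot be ordered against each other. Among the compounds with values here, compound 3 `COc1cccc(Cn2ccc3cnc(Nc4cnn(CCCCCC(=O)NO)c4)nc32)c1` gives 37.6 nM; the step of a 2.7-fold higher number from compound 1 to compound 3 (0.44 log units; beyond the scatter) is a modest loss and is the only measured change at the ring on the chain end of the shared core.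

Compound 4 `O=C(CCCCCCn1cc(Nc2ncc3ccn(CC4CCCCC4)c3n2)cn1)NO` has not been measured. Relative to compound 2 it carries cyclohexyl in place of phenyl on a saturated chain carbon bound to an aromatic nitrogen. Within the data shown here, no measured step tests this exchange of an aromatic ring for a saturated one; the only change made at that ring, a 2.7-fold higher number from compound 1 to compound 3 (0.44 log units; beyond the scatter), was modest, which suggests that ring is not the part of the molecule that drives the number. The step of a 1.4-fold higher number from compound 2 to compound 4 (0.16 log units; within the scatter) is therefore expected to be small, at most a slight weakening, with wide uncertainty. Compound 4 is estimated to give 18 nM, within a range from 7 nM to 45 nM.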

Compound 4, half-maximal inhibitory concentration: 88 nM
The estimate for compound 4 lay 4.9-fold (0.69 log units) below the measured number; measured number above the stated range.
By their numbers in this assay, from the lowest: compounds 2 and 1 (each within the scatter of the next); then compound 3; then compound 4.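

With the step of a 7.0-fold higher number from compound 2 to compound 4 (0.85 log units; beyond the scatter) in this assay, the group on the saturated chain carbon bound to an aromatic nitrogen proves able to move the number by more than the earlier change at that ring, a 2.7-fold higher number from compound 1 to compound 3 (0.44 log units; beyond the scatter). Phenyl and cyclohexyl match in heavy atoms, hydrogen-bond donors, hydrogen-bond acceptors and net charge, so in this pair the computed difference is an aromatic ring against a non-aromatic ring of the same size. Nothing at hand gives a reason for the loss.

Still open, from the compounds shown here alone, is whether a pyridine ring in place of phenyl retains the number of compound 2 or falls toward that of compound 4. Also open, going by these compounds, is whether cyclohexylmethyl in place of benzyl costs as much on the shorter chain of compound 1.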